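A few compounds are considered here, and "the series" means these few. Any claim that something is new, unique, unknown or untested is made for them only; others in the source may bear on it.

Compound 3, `NN1C(=O)/C(=C/c2c[nH]c3ccc(Br)cc23)SC1=S`, stands at the upper edge of what the data show. In a functional assay on T47D cells (Homo sapiens) for cytotoxicity, read by MTT assay, with a stated time of 72 h (on this read-out lower numbers stand for stronger inhibition and higher numbers for weaker inhibition), compound 3 gives > 50000 nM, which is a limit of the assay and not a number. The same holds for its relatives. Compound 1, `NN1C(=O)/C(=C/c2c[nH]c3ccccc23)SC1=S`, gives > 50000 nM in this assay, a limit. Compound 2, `O=C1NC(=S)S/C1=C\c1c[nH]c2ccccc12`, gives > 50000 nM in this assay, again a limit. All three values sit at the limit of > 50000 nM in this assay, at which 3 of the 3 values shown sit, so the two measured steps, a step that the two limits leave unreadable from compound 1 to compound 2 and a step that the two limits leave unreadable from compound 1 to compound 3, have no readable size.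

Compound 4, `O=C1NC(=S)S/C1=C\c1c[nH]c2ccc(Br)cc12`, differs from compound 3 by hydrogen in place of amino on an amide-type nitrogen in a ring. Among the compounds with values here, the step that bears most directly on it is the one from compound 1 to compound 2, the same exchange on the same nitrogen, and that step was left unreadable by two limits. Within the data shown here, no measured step therefore gives any direction, and compound 4 is expected to remain at the limit, with the step from compound 3 to compound 4 estimated as a step that the limit leaves unreadable from compound 3 to compound 4. Compound 4 is accordingly expected to give about 80000 nM, within a range from 30000 nM to 300000 nM.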

Compound 4, half-maximal inhibitory concentration: 11700 nM
Estimate against measurement, compound 4: 6.8-fold (0.83 log units) above; the whole stated range lies above it.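

In this assay, the exchange of amino for hydrogen on the amide-type nitrogen in a ring gives a readable change when the bromo group is present, with an at least 4.2-fold lower number from compound 3 to compound 4 (0.63 log units; beyond the scatter). With that nitrogen carrying hydrogen, bromo in place of hydrogen on an aromatic carbon also counts, with an at least 4.2-fold lower number from compound 2 to compound 4 (0.63 log units; beyond the scatter), whereas the steps from compound 1 cannot be read. Only the compound combining hydrogen on that nitrogen with bromo leaves the limit, and both steps are minimum sizes, as compound 2 and compound 3 each stand at a limit: the limit of > 50000 nM in this assay, at which 3 of the 4 values shown sit.

As far as these compounds go, how far compound 1, compound 2 and compound 3 lie past that limit remains open. So does whether a methyl group on that nitrogen, or chloro in place of bromo, would also give a readable number.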